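Removing one methoxy from the trimethoxyphenyl of compound 1

This account rests on a few compounds, and the source may have more. Where it says the series, first, only, none or still open, it means among the compounds named here.

Compound 1 `COc1cc(-c2cc(/C=C/C(=O)c3ccc(N)cc3)[nH]n2)cc(OC)c1OC` gives 3210 nM in a functional assay on MDA-MB-435 cells (Homo sapiens) for inhibition, read by sulforhodamine B assay, with a stated time of 48 h; on this read-out higher numbers stand for weaker inhibition of growth and lower numbers for stronger inhibition of growth.
Compound 2 `COc1ccc(-c2cc(/C=C/C(=O)c3ccc(OC)c(OC)c3)[nH]n2)cc1` gives 3880 nM in this assay.
Compound 3 `COc1cc(-c2cc(/C=C/C(=O)c3ccc(Cl)c(Cl)c3)[nH]n2)cc(OC)c1OC` gives only a limit of the assay, > 100000 nM.

Among the numbers shown, compound 1 stands lowest of two, with compound 2 within the scatter of it; the third value is the limit of compound 3. Among the measured compounds shown here, the only step between measured compounds is an at least 31-fold higher number from compound 1 to compound 3 (1.49 log units; beyond the scatter), a change of the group on the carbonyl carbon; one of the three values sits at the limit of > 100000 nM in this assay, at which 1 of the 3 values shown sits, so the size of that step is known only as a lower bound.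

Compound 4 `COc1ccc(-c2cc(/C=C/C(=O)c3ccc(N)cc3)[nH]n2)cc1OC` differs from compound 1 in a different place: hydrogen in place of methoxy on an aromatic carbon. No measured step concerns the ring carrying the methoxy groups, so nothing shown speaks directly to this change. Compound 2, which carries fewer methoxy groups on that ring but a different group on the carbonyl carbon, lies within the scatter of compound 1. The account therefore expects no step beyond the scatter from compound 1 to compound 4 in this assay. The value expected for compound 4 is 4000 nM, with a range from 1500 nM to 12000 nM, a step of a 1.2-fold higher number from compound 1 to compound 4 (0.10 log units; within the scatter).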

Compound 4, concentration for total growth inhibition: 7230 nM
Beside the measured number, compound 4's estimate is 1.8-fold (0.26 log units) below it; low and high end bracket the measured number.
By their numbers in this assay, from the lowest: compounds 1, 2 and 4 (each within the scatter of the next, the first and the last beyond it). At a limit, above all of these: compound 3.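

In this assay the ring carrying the methoxy groups now has a measured step of its own, which shows a 2.3-fold higher number from compound 1 to compound 4 (0.35 log units; beyond the scatter) when hydrogen takes the place of a methoxy group on an aromatic carbon. So this methoxy group, ortho to one methoxy group and meta to another, is not interchangeable with hydrogen here, although the step is modest and the inhibition of growth weakens without being lost. Nothing shown gives a reason for this step.

The compounds shown leave open whether a hydroxyl group, an ethoxy group or a fluorine atom at this place would keep the number of compound 1 or move it as hydrogen does. They also leave open whether the same change would have a step of similar size with a group other than 4-aminophenyl on the carbonyl carbon.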